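A few compounds are considered here, and "the series" means these few. Any claim that something is new, unique, unknown or untested is made for them only; others in the source may bear on it.

Measured in an in vitro ADME assay on microsomes from liver (Simiiformes); on this read-out lower numbers stand for a shorter-lived compound and higher numbers for a longer-lived compound:
compound 1 `COCc1cc(CCCOc2c(C)cc(-c3noc(C(F)(F)F)n3)cc2C)on1`: 1.58 h
compound 2 `Cc1cc(CCCOc2c(C)cc(-c3noc(CF)n3)cc2C)on1`: 0.233 h

Of these two numbers, compound 2 at 0.233 h holds the lower place, and compound 1 at 1.58 h stands higher by a gap beyond the usual scatter. The two structures differ in more than one place, so that gap cannot be assigned to any single change.

Compound 3 `Cc1cc(CCCOc2c(C)cc(-c3noc(C4CC4)n3)cc2C)on1` has not yet been measured. It carries cyclopropyl in place of fluoromethyl on an aromatic carbon of the five-membered ring (cyclopropyl in place of fluoromethyl on an aromatic carbon), and the rest of the structure of compound 2 stays as it is. Among the compounds with values here, no measured pair isolates a change of this kind, so the expectation in this assay is a loose one. With compound 2 at 0.233 h, the lower of the two numbers, a modest rise is expected rather than a fall, and it may not clear the scatter. The estimated change is a 1.7-fold higher number from compound 2 to compound 3 (0.23 log units; within the scatter). The expected half-life of compound 3 is 0.4 h, within an estimated range of 0.15 h to 1.2 h.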

Compound 3, half-life: 2.23 h
The estimate for compound 3 lay 5.6-fold (0.75 log units) below the measured number; measured number outside the range, above it.
By their numbers in this assay, from the lowest: compound 2; then compounds 1 and 3 (each within the scatter of the next).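

In this assay, within the data shown here, the exchange of 5-(fluoromethyl)-1,2,4-oxadiazol-3-yl for 5-cyclopropyl-1,2,4-oxadiazol-3-yl gives a 9.6-fold higher number from compound 2 to compound 3 (0.98 log units; beyond the scatter), and this is the first step here that can be read at a single place. The earlier pair differed in more than one place, whereas here the rest of the structure stays as it is, so the whole step belongs to this one exchange on an aromatic carbon of the five-membered ring, next to the ring nitrogen and next to the ring oxygen. Nothing measured here accounts for the size of the step, and its cause remains unknown.

The compounds shown leave open how a cyclobutyl or an ethyl group would stand at this same position against fluoromethyl and cyclopropyl. They also leave open whether cyclopropyl in place of fluoromethyl would give a step of similar size on the core of compound 1, where a methoxymethyl group replaces the methyl group on the other five-membered ring.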